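This account rests on a few compounds, and the source may have more. Where it says the series, first, only, none or still open, it means among the compounds named here.

Of the compounds shown here, three that share a core have been tested in a functional assay on the whole organism (strain Wistar) for inhibition, with Rattus norvegicus as the target, with stated times of 30 min and 2 h, at a dose of 20 mg/kg by the oral route; a lower number here means less inhibition, a higher number more inhibition at the dose given (going by the name of the read-out). Compound 1, `O=C(CCc1nnc(-c2ccccc2Cl)o1)c1ccccc1`, gives 26.9% in this assay. Compound 2, `O=C(CCc1nnc(-c2ccc(Cl)cc2)o1)c1ccccc1`, differs from compound 1 only by 4-chlorophenyl in place of 2-chlorophenyl on an aromatic carbon, and in this assay compound 2 gives 42%; the step of a number 15.1 percentage points higher from compound 1 to compound 2 (beyond the scatter). Compound 3, `Cc1ccc(C(=O)CCc2nnc(-c3ccccc3Cl)o2)c(C)c1`, differs from compound 1 by 2,4-dimethylphenyl in place of phenyl on a carbonyl carbon, and in this assay compound 3 gives 33.5%; the step of a number 6.6 percentage points higher from compound 1 to compound 3 (within the scatter), so compounds 1 and 3 cannot be told apart on this read-out.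

Compound 4, `Cc1ccc(C(=O)CCc2nnc(-c3ccc(Cl)cc3)o2)c(C)c1`, has not yet been measured. It differs from compound 3 by 4-chlorophenyl in place of 2-chlorophenyl on an aromatic carbon. This is the same change that turns compound 1 into compound 2, made at the same place on the shared core; it occurs twice among these four compounds. The two cores on which it is made differ from each other by the change from phenyl to 2,4-dimethylphenyl on the carbonyl carbon described above.

Among the measured compounds shown here, since the only measured instance of this change is the step of a number 15.1 percentage points higher from compound 1 to compound 2 (beyond the scatter), and since the change from compound 1 to compound 3 did not move the read-out beyond its scatter, a step of similar direction and size is expected here. The expected step is a number 12.5 percentage points higher from compound 3 to compound 4 (beyond the scatter). On that basis compound 4 is expected to give 46% in this assay, with a likely range from 34% to 58%, the wider span reflecting that a single prior step is thin support.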

Compound 4, a percentage reported as inhibition, in the whole organism at one dose (the size of the read-out at that dose, not a potency): 53.3%
Estimate against measurement, compound 4: 7.3 percentage points below; low and high end bracket the measured number.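

In this assay, with 2,4-dimethylphenyl on the carbonyl carbon, putting 4-chlorophenyl in place of 2-chlorophenyl gives a step of a number 19.8 percentage points higher from compound 3 to compound 4 (beyond the scatter), and this agrees with the same change on the core of compound 1: the same change on two cores in this assay, a number 15.1 percentage points higher (beyond the scatter) from compound 1 to compound 2 and a number 19.8 percentage points higher (beyond the scatter) from compound 3 to compound 4, 4.7 percentage points apart, within the scatter of two such steps The other change, 2,4-dimethylphenyl in place of phenyl, gives a step of a number 11.3 percentage points higher from compound 2 to compound 4 (beyond the scatter), and its two instances also agree, although only this one lies beyond the scatter: the same change on two cores in this assay, a number 6.6 percentage points higher (within the scatter) from compound 1 to compound 3 and a number 11.3 percentage points higher (beyond the scatter) from compound 2 to compound 4, 4.7 percentage points apart, within the scatter of two such steps Among these four compounds, each change therefore carries over from one core to the other with much the same size, but two cores are a very small sample, so this does not show that the steps would hold on other cores, and a reading at one dose does not show why the numbers move or give a potency.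

The compounds shown leave open what a methoxy group or an amine in place of the chlorine would do to this read-out. They also leave open whether the steps would survive a longer chain between the carbonyl and the five-membered aromatic ring.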